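Aryl sulfone exchange: from compound 2 to compound 3

The compounds below may be only part of what the source reports. "The series", "measured", "known", "first", "only" and "open" are said of these compounds alone.

Measured so far:
compound 1 `COc1ccc2ncc(S(=O)(=O)c3cc(C)cc(C)c3)c(N3CCC(C)CC3)c2c1` — 79%
compound 2 `COc1ccc2ncc(S(=O)(=O)c3ccc(OC)c(OC)c3)c(N3CCC(C)CC3)c2c1` — -3%

In an assay on isolated protein for displacement of a labelled ligand from metabotropic glutamate receptor 5 (Homo sapiens), with a stated time of 60 min, tested at 1 uM (on this read-out higher numbers stand for more inhibition at the one concentration tested (going by the name of the read-out) and lower numbers for less inhibition), compound 2 stands lowest of the two values, with compound 1 above it. Going by the values given here, the one step on record, a number 82 percentage points lower from compound 1 to compound 2 (beyond the scatter), shows that exchanging the aryl group on the sulfonyl sulfur can move this assay by a large amount. Compound 3 `COc1ccc2ncc(S(=O)(=O)c3cccc(F)c3)c(N3CCC(C)CC3)c2c1` differs from compound 2 by 3-fluorophenyl in place of 3,4-dimethoxyphenyl on a sulfonyl sulfur. Among the compounds with values here, with only that step to go on, a rise beyond the scatter is expected, its size uncertain. Compound 3 is therefore expected to give 50% (range 10% to 85%), an estimated a number 53 percentage points higher from compound 2 to compound 3 (beyond the scatter).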

Compound 3, a percentage reported as inhibition, at one concentration (the size of the read-out at that concentration, not a potency): 68%
Beside the measured number, compound 3's estimate is 18 percentage points below it; the range from low to high includes it.
By their numbers in this assay, from the lowest: compound 2; then compound 3; then compound 1.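

The aryl group on the sulfonyl sulfur in this assay does not need the two methyl groups of compound 1 for a high number: 3-fluorophenyl also gives one (a number 71 percentage points higher from compound 2 to compound 3 (beyond the scatter)). A gap beyond the scatter still separates the two aryl groups (a number 11 percentage points lower from compound 1 to compound 3 (beyond the scatter)), though it is far smaller than the gap to 3,4-dimethoxyphenyl. No measurement here explains these differences. From the compounds shown here alone, whether one methoxy group alone, as in 3-methoxyphenyl or 4-methoxyphenyl, gives the low number remains open. So does how unsubstituted phenyl or 3-chlorophenyl would compare.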